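Nitrofuran thiazole amides: halogen to ethoxy step

The compounds below may be only part of what the source reports. "The series", "measured", "known", "first", "only" and "open" are said of these compounds alone.

Measured compounds:
Compound 1, `O=C(Nc1nc(-c2cccc(F)c2)cs1)c1ccc([N+](=O)[O-])o1`: in an ADME assay on Vero cells (Chlorocebus sabaeus) for cytotoxicity, read by MTT assay, with a stated time of 72 h (on this read-out higher numbers stand for weaker inhibition and lower numbers for stronger inhibition), compound 1 gives 51600 nM.
Compound 2, `O=C(Nc1nc(-c2cccc(Cl)c2)cs1)c1ccc([N+](=O)[O-])o1`: compound 2 gives 43700 nM.
Compound 3, `O=C(Nc1nc(-c2cccc(Br)c2)cs1)c1ccc([N+](=O)[O-])o1`: compound 3 gives 71000 nM.

Compound 3 sits at the upper end of the three numbers, though the steps separating it from the others are within the scatter: a 1.4-fold higher number from compound 1 to compound 3 (0.14 log units; within the scatter) and a 1.6-fold higher number from compound 2 to compound 3 (0.21 log units; within the scatter). The remaining step among the measured set, a 1.2-fold lower number from compound 1 to compound 2 (0.07 log units; within the scatter), is likewise within the scatter, so the three halogen variants cannot be told apart on this read-out.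

Compound 4, `CCOc1cccc(-c2csc(NC(=O)c3ccc([N+](=O)[O-])o3)n2)c1`, is the next point: ethoxy in place of bromo on an aromatic carbon. Within the data shown here, none of the measured steps bears directly on this change; all three concern the exchange of one halogen for another on the same aromatic carbon, and every one of them stayed within the scatter. The series therefore offers no indication of a move in either direction for an ethoxy group entering in place of bromo, and the step of a 1.3-fold lower number from compound 3 to compound 4 (0.11 log units; within the scatter) is expected to remain within the scatter. On that basis compound 4 is estimated at 55000 nM, with a range from 25000 nM to 120000 nM.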

Compound 4, half-maximal inhibitory concentration: > 90000 nM
Compound 4 was reported as a limit; the forecaster's own chance of this, stated with the estimate: 20%; at least 1.6-fold (0.21 log units) between middle value and limit.
By their numbers in this assay, from the lowest: compounds 2, 1 and 3 (each within the scatter of the next). At a limit, above all of these: compound 4.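

In this assay, among these compounds, compound 4 is reported as a limit and not as a number, and it is the only compound reported this way: the limit of > 90000 nM in this assay, at which 1 of the 4 values shown sits. Ethoxy on this aromatic carbon, meta to a large group, gives the first step in the series that is beyond the scatter, an at least 2.0-fold higher number from compound 2 to compound 4 (0.31 log units; beyond the scatter), and it points towards weaker inhibition, whereas the exchanges of one halogen for another all stayed within the scatter. On these data alone, the other two steps, an at least 1.2-fold higher number from compound 3 to compound 4 (0.10 log units; that floor lies within the scatter) and an at least 1.7-fold higher number from compound 1 to compound 4 (0.24 log units; that floor lies within the scatter), are floors that lie within the scatter, so at this stage ethoxy is separated clearly only from chloro, and the real size of all three steps remains unknown.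

The compounds shown do not tell whether the shift belongs to the ring-bound oxygen or to the two-carbon chain, a question that methoxy or a plain ethyl group at the same carbon would address. As far as these compounds go, how this position responds to a longer chain such as butoxy, to an amine or to a carboxylic acid also remains open.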